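The source may report more compounds than this note shows. Statements on the series, on what has been measured and on what is new or still open speak of the compounds shown alone.

Measured so far in a functional assay on HepG2 cells (Homo sapiens) for cytotoxicity, read by MTT assay, with a stated time of 48 h; a lower number here means a stronger inhibitor, a higher number a weaker inhibitor:
Compound 1 `CCCCCCCCCCCCCCNC(=O)[C@@H](NC(=O)c1cc2ccccc2[nH]1)[C@@H](C)O` gives 10500 nM.
Compound 2 `CCCCCCCCCCCCCCNC(=O)[C@@H](NC(=O)c1cc2ccccc2n1C)[C@@H](C)O` gives 34500 nM.
Compound 3 `CCCCCCCCCCCCCCCCCCNC(=O)[C@@H](NC(=O)c1cc2ccccc2[nH]1)[C@@H](C)O` gives 89400 nM.

Compound 4 `CCCCCCCCCCCCCCCCCCNC(=O)[C@@H](NC(=O)c1cc2ccccc2n1C)[C@@H](C)O` has not yet been measured in this assay. It differs from compound 3 by methyl in place of hydrogen on an aromatic nitrogen. The same change, (methyl in place of hydrogen on an aromatic nitrogen), has been made once before, and there it gave a 3.3-fold higher number from compound 1 to compound 2 (0.52 log units; beyond the scatter). The two cores that carry this change differ by butyl in place of hydrogen on a saturated chain carbon, ten or more bonds along the chain from an amide-type nitrogen, a difference that by itself gave an 8.5-fold higher number from compound 1 to compound 3 (0.93 log units; beyond the scatter). Because compound 3 already gives 89400 nM as the highest of the three numbers, a further step of the earlier size would carry compound 4 beyond the range in which any of the three compounds has been measured. The step is expected to be about a 3.1-fold higher number from compound 3 to compound 4 (0.50 log units; beyond the scatter), resting on the earlier step of a 3.3-fold higher number from compound 1 to compound 2 (0.52 log units; beyond the scatter). Compound 4 is therefore estimated at 280000 nM, with a likely range from 100000 nM to 700000 nM.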

Compound 4, half-maximal inhibitory concentration: > 200000 nM
Compound 4 gave a limit, no number; the forecaster's own chance of this, stated with the estimate: 40%; the middle value lies beyond the limit too.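

In this assay compound 4 gives > 200000 nM, which is a limit of the assay and not a number. Methyl in place of hydrogen on the aromatic nitrogen gives an at least 2.2-fold higher number from compound 3 to compound 4 (0.34 log units; beyond the scatter), so the change raises the number on both cores, but only its direction carries over, not a known size: the same change on two cores in this assay, a 3.3-fold higher number (0.52 log units; beyond the scatter) from compound 1 to compound 2 and an at least 2.2-fold higher number (0.34 log units; beyond the scatter) from compound 3 to compound 4; the limit leaves it open whether they differ. The longer chain, butyl in place of hydrogen on a saturated chain carbon, likewise gives an at least 5.7-fold higher number from compound 2 to compound 4 (0.76 log units; beyond the scatter), again the same direction with its size unsettled: the same change on two cores in this assay, an 8.5-fold higher number (0.93 log units; beyond the scatter) from compound 1 to compound 3 and an at least 5.7-fold higher number (0.76 log units; beyond the scatter) from compound 2 to compound 4; the limit leaves it open whether they differ.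

The compounds shown leave open whether a chain shorter than that of compound 1 would give a lower number. They also leave open how ethyl on the aromatic nitrogen would compare with methyl.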